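Thiosemicarbazone series: nitro-to-chloro swap on the aryl ring

This account rests on a few compounds, and the source may have more. Where it says the series, first, only, none or still open, it means among the compounds named here.

Measured so far:
compound 1, `C/C(=N/NC(=S)Nc1ccc(Cl)cc1)c1ccccn1`: 1.7 nM
compound 2, `C/C(=N/NC(=S)Nc1ccccc1[N+](=O)[O-])c1ccccn1`: 4.3 nM
compound 3, `C/C(=N/NC(=S)Nc1ccc([N+](=O)[O-])cc1)c1ccccn1`: 160 nM

All three were read in a functional assay on U-87MG ATCC cells (Homo sapiens) for cytotoxicity, read by MTT assay, with a stated time of 48 h; on this read-out lower numbers stand for stronger inhibition and higher numbers for weaker inhibition. Among the measured compounds shown here, the one counted step is chloro in place of nitro on an aromatic carbon, which gave a 94-fold lower number from compound 3 to compound 1 (1.97 log units; beyond the scatter). Compound 2 and compound 3 share the same atoms joined differently; the difference between the two cores is not broken down here, and their values simply show compound 2 well below compound 3.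

Compound 4, `C/C(=N/NC(=S)Nc1ccccc1Cl)c1ccccn1`, is not yet measured. It differs from compound 2 by chloro in place of nitro on an aromatic carbon, the same kind of change as that from compound 3 to compound 1, but placed ortho to a large group rather than para to a large group. Starting from the already low number of compound 2, a smaller step is expected, a 2.9-fold lower number from compound 2 to compound 4 (0.46 log units; beyond the scatter), smaller than the earlier step because a 94-fold lower number from compound 3 to compound 1 (1.97 log units; beyond the scatter) rests on a different place on the ring. Compound 4 is estimated at 1.5 nM, with a likely range of 0.4 nM to 6 nM.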

Compound 4, half-maximal inhibitory concentration: 2.6 nM
Estimate against measurement, compound 4: 1.7-fold (0.24 log units) below; the range from low to high includes it.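

In this assay, chloro in place of nitro on an aromatic carbon does not carry a single step size from one core to the other: the same change on two cores in this assay, a 94-fold lower number (1.97 log units; beyond the scatter) from compound 3 to compound 1 and a 1.7-fold lower number (0.22 log units; within the scatter) from compound 2 to compound 4, 57-fold (1.76 log units) apart, beyond the scatter of two such steps. Ortho to a large group, the change gives a 1.7-fold lower number from compound 2 to compound 4 (0.22 log units; within the scatter), so the large step seen on the other core does not reappear here. Among the compounds shown here, with only one pair on each side, this shows that the step does not transfer, but it does not show how far the place on the ring accounts for the gap, or why the gap arises.

Still open, as far as these compounds go, is whether an amine or a carboxylic acid at this place would keep numbers as low as those of compound 2 and compound 4. Also open, from the compounds shown here alone, is how the same change behaves on any further core.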